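A few compounds are considered here, and "the series" means these few. Any claim that something is new, unique, unknown or untested is made for them only; others in the source may bear on it.

Three compounds that share one core and differ only in the group carried on a saturated chain carbon bound to an oxygen on an unsaturated carbon and a triple-bonded carbon have been tested in a functional assay on SW1573 cells (Homo sapiens) for antiproliferative activity, read by sulforhodamine B assay, with a stated time of 48 h; on this read-out higher numbers stand for weaker inhibition of growth and lower numbers for stronger inhibition of growth. Compound 1 `COC(=O)C#CC(O/C=C/C(=O)OC)C1CC1` gives 1800 nM, compound 2 `CCCCCC(C#CC(=O)OC)O/C=C/C(=O)OC` gives 1700 nM, and compound 3 `CCC(C)C(C#CC(=O)OC)O/C=C/C(=O)OC` gives 910 nM. Compound 3 carries the lowest of the three numbers, but the steps of a 2.0-fold lower number from compound 1 to compound 3 (0.30 log units; within the scatter) and a 1.9-fold lower number from compound 2 to compound 3 (0.27 log units; within the scatter) are both within the scatter, as is a 1.1-fold lower number from compound 1 to compound 2 (0.02 log units; within the scatter), so the three compounds cannot be told apart on these data.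

Compound 4 `CCC(C#CC(=O)OC)O/C=C/C(=O)OC` has not yet been measured. It differs from compound 3 in one place: hydrogen in place of ethyl on a saturated chain carbon bound to two saturated chain carbons. The measured steps that bear on this change are the exchanges of one group for another at that same chain carbon, and none of them moved the number beyond the scatter. The expectation is therefore that the step of a 1.3-fold higher number from compound 3 to compound 4 (0.12 log units; within the scatter) will also stay within the scatter, with no clear direction. Compound 4 is estimated at 1200 nM, with an expected range from 500 nM to 3000 nM.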

Compound 4, concentration for 50% growth inhibition: 540 nM
Estimate against measurement, compound 4: 2.2-fold (0.35 log units) above; low and high end bracket the measured number.
By their numbers in this assay, from the lowest: compounds 4, 3, 2 and 1 (each within the scatter of the next, the first and the last beyond it).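

In this assay the ethyl group of compound 4 brings the first separation beyond the scatter among groups on the saturated chain carbon bound to an oxygen on an unsaturated carbon and a triple-bonded carbon, modest in both cases (a 3.1-fold lower number from compound 2 to compound 4 (0.50 log units; beyond the scatter)) and (a 3.3-fold lower number from compound 1 to compound 4 (0.52 log units; beyond the scatter)). The change of hydrogen in place of ethyl on a saturated chain carbon bound to two saturated chain carbons stays within the scatter (a 1.7-fold lower number from compound 3 to compound 4 (0.23 log units; within the scatter)). The sec-butyl group of compound 3 therefore cannot be told apart from any of the other three groups, while ethyl can be told apart from pentyl and cyclopropyl.

The compounds shown leave open what a methyl group, a phenyl ring or an amine would give at this carbon. Nothing measured here accounts for these differences.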